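The compounds below may be only part of what the source reports. "The series", "measured", "known", "first", "only" and "open" are said of these compounds alone.

Three measured compounds share one core and differ only in the group carried on a saturated chain carbon bound to an amine nitrogen. In a functional assay on BE(2)-C cells (Homo sapiens) for inhibition, read by MTT assay, with a stated time of 72 h (a higher number here means a weaker inhibitor of growth, a lower number a stronger inhibitor of growth), compound 1 `O=S(=O)(NCCCNCc1cccc2ccccc12)c1cc(C(F)(F)F)cc(C(F)(F)F)c1` gives 2700 nM, compound 2 `COc1cccc(CNCCCNS(=O)(=O)c2cc(C(F)(F)F)cc(C(F)(F)F)c2)c1` gives 4500 nM, and compound 3 `O=S(=O)(NCCCNCc1cccc(Cl)c1)c1cc(C(F)(F)F)cc(C(F)(F)F)c1` gives 6900 nM, the highest of the three numbers. The step of a 2.6-fold higher number from compound 1 to compound 3 (0.41 log units; beyond the scatter) is modest, while a 1.5-fold higher number from compound 2 to compound 3 (0.19 log units; within the scatter) and a 1.7-fold higher number from compound 1 to compound 2 (0.22 log units; within the scatter) stay within the scatter. Compound 4 `O=S(=O)(NCCCNCc1ccc(C(F)(F)F)cc1)c1cc(C(F)(F)F)cc(C(F)(F)F)c1` is the next candidate: 4-(trifluoromethyl)phenyl in place of 3-chlorophenyl on a saturated chain carbon bound to an amine nitrogen. Within the data shown here, the only comparable measured step, a swap of one substituent on an aromatic carbon, was a 1.5-fold higher number from compound 2 to compound 3 (0.19 log units; within the scatter), so no step beyond the scatter is expected here. Compound 4 is therefore estimated at 6000 nM, within a range of 2500 nM to 14000 nM. That estimate means an expected step of a 1.2-fold lower number from compound 3 to compound 4 (0.06 log units; within the scatter).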

Compound 4, concentration for 50% growth inhibition: 2700 nM
Estimate against measurement, compound 4: 2.2-fold (0.35 log units) above, within the range that was stated.
By their numbers in this assay, from the lowest: compounds 1, 4, 2 and 3 (each within the scatter of the next, the first and the last beyond it).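

The change to 4-(trifluoromethyl)phenyl gives a 2.6-fold lower number from compound 3 to compound 4 (0.41 log units; beyond the scatter) and shows that a swap between two substituted phenyl groups at this position can pass the scatter, which no such swap had done before. The same group gives a 1.7-fold lower number from compound 2 to compound 4 (0.22 log units; within the scatter) and also no change at the digits printed from compound 1 to compound 4 (within the scatter) and so shows that naphthalen-1-yl is not needed to reach this number. No measurement here explains these differences.

Still open, from the compounds shown here alone, is how a phenyl group carrying a nitrile or a carboxylic acid would read in this assay, and what a longer chain in the shared core would do.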